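N-substituent variation in a thiophenylmethyl aryloxyacetamide series

The source may report more compounds than this note shows. Statements on the series, on what has been measured and on what is new or still open speak of the compounds shown alone.

Compound 1 `Cc1ccc(OCC(=O)N(Cc2cccs2)c2cnn(C)c2)cc1`: 63000 nM
Compound 2 `Cc1ccc(OCC(=O)N(C)Cc2cccs2)cc1`: 400 nM
Compound 3 `Cc1ccc(OCC(=O)N(Cc2cccs2)C2CC2)cc1`: 8 nM

In an assay on HEK293 cells for agonist activity at transient receptor potential cation channel subfamily M member 8 (Homo sapiens), read by fluorescence and calcium flux, with a stated time of 15 min (on this read-out lower numbers stand for an effect already at smaller amounts and higher numbers for an effect only at larger amounts of compound), compound 3 gives the lowest of the three numbers: compound 2 stands a 50-fold lower number from compound 2 to compound 3 (1.70 log units; beyond the scatter) away, compound 1 a 7900-fold lower number from compound 1 to compound 3 (3.90 log units; beyond the scatter) away, and between those two a 160-fold lower number from compound 1 to compound 2 (2.20 log units; beyond the scatter) is seen. The group on the amide-type nitrogen thus moves the read-out strongly across the measured set.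

Compound 4 `Cc1ccc(OCC(=O)N(Cc2cccs2)C(C)C)cc1` differs from compound 3 by isopropyl in place of cyclopropyl on an amide-type nitrogen. Within the data shown here, no measured step exchanges two groups of the same atom count at this place; the three steps seen each change the size of the group, and all are large. Since the entering group matches the leaving one in count, a small step at most is expected, a 1.9-fold higher number from compound 3 to compound 4 (0.27 log units; within the scatter), in the direction of a higher number if any.

Compound 4 is expected at 15 nM (range 4 nM to 60 nM).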

Compound 4, half-maximal effective concentration: 70 nM
Beside the measured number, compound 4's estimate is 4.7-fold (0.67 log units) below it; measured number above the stated range.
By their numbers in this assay, from the lowest: compound 3; then compound 4; then compound 2; then compound 1.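

In this assay, a change that keeps the heavy-atom count still shifts the read-out (an 8.8-fold higher number from compound 3 to compound 4 (0.94 log units; beyond the scatter)), so at this amide-type nitrogen that count alone does not set the number, and cyclopropyl and isopropyl differ in the three-membered ring. Isopropyl also gives lower numbers than methyl (a 5.7-fold lower number from compound 2 to compound 4 (0.76 log units; beyond the scatter)) and 1-methyl-1H-pyrazol-4-yl (a 900-fold lower number from compound 1 to compound 4 (2.95 log units; beyond the scatter)), placing it inside the measured order rather than at its low end. Nothing available explains the gap between the ring and the open group.

Cyclobutyl and ethyl on this nitrogen remain open. It therefore stays unsettled whether the lowest number belongs to the three-membered ring specifically.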